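The compounds below may be only part of what the source reports. "The series", "measured", "known", "first", "only" and "open" are said of these compounds alone.

Compound 1, `O=c1c(S(=O)(=O)c2ccc(F)cc2F)cc2cnc(Nc3ccc4[nH]ccc4c3)nc2n1C1CC1`, is one of three compounds tested in a functional assay on DU-145 cells (Homo sapiens) for inhibition, read by trypan blue exclusion, with a stated time of 72 h; a lower number here means a stronger inhibitor, a higher number a weaker inhibitor. Compound 1 gives 500 nM. Compound 2, `Cn1c(=O)c(S(=O)(=O)c2ccc(F)cc2)cc2cnc(Nc3cnc4[nH]ccc4c3)nc21`, gives 500 nM in this assay, so compound 1 and compound 2 stand level at the digits shown, and together they are the lowest of the three numbers. Compound 3, `Cn1c(=O)c(S(=O)(=O)c2ccc(F)cc2)cc2cnc(Nc3ccc4[nH]ncc4c3)nc21`, gives 5000 nM in this assay, the furthest from compound 1.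

Among the compounds with values here, the only single-point step among the measured compounds is the one from compound 2 to compound 3, where the group attached to the amine nitrogen is exchanged: a 10-fold higher number from compound 2 to compound 3 (1.00 log units; beyond the scatter).

Compound 4, `O=c1[nH]c2nc(Nc3ccc4[nH]ccc4c3)ncc2cc1S(=O)(=O)c1ccc(F)cc1F`, is not yet measured. It differs from compound 1 in one place: hydrogen in place of cyclopropyl on an aromatic nitrogen. The nitrogen of the shared core loses its cyclopropyl and carries only a hydrogen atom.

Within the data shown here, no measured step touches this position; the step from compound 2 to compound 3 concerns a different part of the molecule and so does not bear on it. With nothing to point one way or the other, the expectation for compound 4 in this assay is a number close to that of compound 1, with no step beyond the scatter, which is expressed as a 1.4-fold higher number from compound 1 to compound 4 (0.15 log units; within the scatter). The estimated value for compound 4 is 700 nM, expected to lie between 200 nM and 3000 nM.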

Compound 4, half-maximal inhibitory concentration: 15000 nM
Estimate against measurement, compound 4: 21-fold (1.33 log units) below, outside the stated range (above it).
By their numbers in this assay, from the lowest: compounds 1 and 2 (each within the scatter of the next); then compound 3; then compound 4.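

In this assay the step of a 30-fold higher number from compound 1 to compound 4 (1.48 log units; beyond the scatter) shows that this aromatic nitrogen of the shared core is far from a neutral place in the molecule: with the cyclopropyl gone and only hydrogen left, the compound is much weaker, well beyond the scatter. Within the data shown here, until now the only readable change was in the group on the amine nitrogen, so this is the first sign that a second place in these molecules also moves the number strongly. Nothing shown here gives a reason for the size of this loss.

Only cyclopropyl and hydrogen can be compared directly at this nitrogen, because compound 2 and compound 3 carry a methyl there but also differ from compound 1 elsewhere, so the effect of that methyl cannot be read. Going by these compounds, it remains open whether an ethyl group, a cyclobutyl ring or a longer chain on this nitrogen would keep the number close to that of compound 1 at 500 nM or shift it further in either direction.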